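The compounds below may be only part of what the source reports. "The series", "measured", "known", "first", "only" and "open" are said of these compounds alone.

Measured in an in vivo functional assay on the whole organism (Rattus norvegicus) with cysteinyl leukotriene receptor (Homo sapiens) as the target; a lower number here means that less compound is needed, a higher number that more compound is needed for the effect:
compound 1 `CCCc1c(COc2ccc(C(=O)C(C)Cc3nnn[nH]3)cc2)ccc(C(C)=O)c1O`: 9.2 mg/kg
compound 2 `CCCc1c(COc2ccc(C(=O)CC(C)(C)CC(=O)O)cc2)ccc(C(C)=O)c1O`: 2.9 mg/kg
compound 3 `CCCc1c(COc2ccc(C(=O)CCCCc3nnn[nH]3)cc2)ccc(C(C)=O)c1O`: 2.4 mg/kg

In this assay compound 3 gives the lowest of the three numbers; compound 2 stands within the scatter of it, only compound 1 beyond it. Compound 4 `CCCc1c(COc2ccc(C(=O)CCCCCCc3nnn[nH]3)cc2)ccc(C(C)=O)c1O` differs from compound 3 in one place: 2-(1H-tetrazol-5-yl)ethyl in place of 1H-tetrazol-5-yl on a saturated chain carbon, four bonds along the chain from a carbonyl carbon. Among the compounds with values here, two measured steps touch the chain carrying the tetrazole: a 3.8-fold lower number from compound 1 to compound 3 (0.58 log units; beyond the scatter), and a 1.2-fold lower number from compound 2 to compound 3 (0.08 log units; within the scatter). Within the data shown here, neither shows the number rising as the chain grows, yet no measured pair compares a chain longer than that of compound 3, so a further fall is not supported. The expected step is therefore a 1.1-fold higher number from compound 3 to compound 4 (0.03 log units; within the scatter), nothing beyond the scatter. Compound 4 is estimated at 2.6 mg/kg, with a range from 1.1 mg/kg to 6.5 mg/kg.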

Compound 4, dose for half-maximal effect: 8.5 mg/kg
Estimate against measurement, compound 4: 3.3-fold (0.51 log units) below; the measured number lies above the stated range.
By their numbers in this assay, from the lowest: compounds 3 and 2 (each within the scatter of the next); then compounds 4 and 1 (each within the scatter of the next).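

In this assay the chain carrying the tetrazole does not tolerate growth at this position: 2-(1H-tetrazol-5-yl)ethyl in place of 1H-tetrazol-5-yl gives a 3.5-fold higher number from compound 3 to compound 4 (0.55 log units; beyond the scatter), the first rise seen with chain growth. The longer chain also separates from the branched acid chain, with a 2.9-fold higher number from compound 2 to compound 4 (0.47 log units; beyond the scatter), and it sits level with the branched tetrazole chain, with a 1.1-fold lower number from compound 1 to compound 4 (0.03 log units; within the scatter), while no available measurement bears on the rise.

As far as these compounds go, whether an intermediate chain length keeps the lower number, and whether a still longer chain goes further, stays open. A carboxylic acid on the unbranched chain in place of the tetrazole is also untested among the compounds shown.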